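Replacing chloroacetamide with cyclopentylurea on the aryl sulfonate core

The source may report more compounds than this note shows. Statements on the series, on what has been measured and on what is new or still open speak of the compounds shown alone.

Compound 1 `CCCC(=O)Nc1ccc(S(=O)(=O)Oc2ccccc2I)cc1`: 9000 nM
Compound 2 `CC(C)c1ccccc1OS(=O)(=O)c1ccc(NC(=O)CCl)cc1`: 3900 nM
Compound 3 `O=C(CCl)Nc1ccc(S(=O)(=O)Oc2ccccc2I)cc1`: 3900 nM

In a functional assay on M21 cells (Homo sapiens) for antiproliferative activity, read by sulforhodamine B assay, with a stated time of 48 h (a lower number here means a stronger inhibitor, a higher number a weaker inhibitor), compound 2 stands level with compound 3 (no change at the digits printed from compound 2 to compound 3 (within the scatter)), the two sharing the lowest number of the three, while compound 1 lies furthest away, separated from compound 3 by a 2.3-fold lower number from compound 1 to compound 3 (0.36 log units; beyond the scatter). Compound 4 `CC(C)c1ccccc1OS(=O)(=O)c1ccc(NC(=O)NC2CCCC2)cc1` differs from compound 2 by cyclopentylamino in place of chloromethyl on a carbonyl carbon. Going by the values given here, no measured step covers this change directly; the only step touching the carbonyl substituent is a 2.3-fold lower number from compound 1 to compound 3 (0.36 log units; beyond the scatter), in which chloro replacing ethyl lowered the number modestly. Compound 4 also gives up the chloro, so for compound 4 a move in the opposite direction, at least of that size, is expected: a 3.8-fold higher number from compound 2 to compound 4 (0.59 log units; beyond the scatter). Compound 4 is accordingly estimated at 15000 nM, with a plausible range from 5000 nM to 50000 nM.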

Compound 4, half-maximal inhibitory concentration: 6100 nM
The estimate for compound 4 lay 2.5-fold (0.39 log units) above the measured number; low and high end bracket the measured number.
By their numbers in this assay, from the lowest: compounds 2, 3, 4 and 1 (each within the scatter of the next, the first and the last beyond it).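

In this assay the carbonyl carbon of compound 2 takes cyclopentylamino in place of chloromethyl with a 1.6-fold higher number from compound 2 to compound 4 (0.19 log units; within the scatter) as the result, so on this core compound 4 stays within the scatter of compound 2 without any chloro. The earlier step (a 2.3-fold lower number from compound 1 to compound 3 (0.36 log units; beyond the scatter)) compared chloro only with ethyl, on the core bearing iodo. Nothing at hand bears on the reason for this result. Still open, going by these compounds, is whether cyclopentylamino behaves alike on the iodo core, and whether a cyclohexylamino group or a plain amine would also stay at this level.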